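Extending the ethylamino chain on compound 1 by one carbon

A few compounds are considered here, and "the series" means these few. Any claim that something is new, unique, unknown or untested is made for them only; others in the source may bear on it.

Measured in a functional assay on the whole organism for inhibition, with Mus musculus as the target, read by paw edema, with a stated time of 180 min, at a dose of 100 mg/kg by the oral route; a higher number here means a stronger effect of the compound at the dose given, a lower number a weaker effect:
compound 1 `CCNc1nnc(Cn2c(=O)oc3ccc(C)cc32)s1` gives 33.8%
compound 2 `Cc1ccc2oc(=O)n(CC(=O)NN)c2c1` gives 70.5%
compound 3 `CCCNC(=S)NNC(=O)Cn1c(=O)oc2ccc(C)cc21` gives 46.1%

Compound 1 has the lowest number of the three in this assay. The nearest neighbour is compound 3, whose value sits above that of compound 1 by more than the scatter, and compound 2 lies furthest above it. Within the data shown here, the one step recorded within the set, a number 24.4 percentage points lower from compound 2 to compound 3 (beyond the scatter), concerns the amine nitrogen of compound 2 and not the chain on the aromatic nitrogen of compound 1.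

Compound 4 `CCCNc1nnc(Cn2c(=O)oc3ccc(C)cc32)s1` differs from compound 1 as follows: methyl in place of hydrogen on a saturated chain carbon, two bonds along the chain from a nitrogen on an aromatic ring. Read one bond further out, this is ethylamino to propylamino. Among the measured compounds shown here, no measured step involves this change, and the step from compound 2 to compound 3 is of a different kind and place. Without a comparable step, no shift beyond the scatter is expected from compound 1. For compound 4 the expected step is a number 2.2 percentage points higher from compound 1 to compound 4 (within the scatter). Compound 4 is therefore estimated at 36%, with a range from 24% to 50%.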

Compound 4, a percentage reported as inhibition, in the whole organism at one dose (the size of the read-out at that dose, not a potency): 31.3%
Beside the measured number, compound 4's estimate is 4.7 percentage points above it; the range from low to high includes it.
By their numbers in this assay, from the lowest: compounds 4 and 1 (each within the scatter of the next); then compound 3; then compound 2.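

In this assay, methyl in place of hydrogen on a saturated chain carbon, two bonds along the chain from a nitrogen on an aromatic ring, gives a number 2.5 percentage points lower from compound 1 to compound 4 (within the scatter), so ethylamino and propylamino cannot be told apart at this dose. Among these compounds, this is the first step read at this position; the only earlier one, a number 24.4 percentage points lower from compound 2 to compound 3 (beyond the scatter), lies on an amine nitrogen in a different part of the series and says nothing about this chain. Nothing at hand explains why the two chains read alike.

From the compounds shown here alone, whether a longer chain such as butyl or a branched chain such as isopropyl would stay within the scatter of compound 1 remains open. So does the effect of a chain ending in an amine or a carboxylic acid.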